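Will a new group on compound 1 stay tolerated?

The source may hold more compounds than are shown below. What is called first, only, known or untested is meant among the compounds shown, and "the series" means these compounds.

Compound 1 `CC(C)[C@H]1C(O)=C(C2=NS(=O)(=O)c3c(O)cccc32)C(=O)N1Cc1ccccc1` gives > 33000 nM in an ADME assay on Huh-7 cells (Homo sapiens) for cytotoxicity, with a stated time of 72 h (a higher number here means that more compound is tolerated, a lower number that less compound is tolerated), as a limit of the assay, not a number. Compound 2 `CC(C)[C@H]1C(O)=C(C2=NS(=O)(=O)c3c(OCC(=O)C(C)(C)C)cccc32)C(=O)N1Cc1ccccc1` gives > 33000 nM there, also a limit. Compound 3 `CC(C)[C@H]1C(O)=C(C2=NS(=O)(=O)c3c(OCC(=O)N4CCOCC4)cccc32)C(=O)N1Cc1ccccc1` gives > 33000 nM there, again a limit. Compound 1 therefore stands with its two relatives at the limit of > 33000 nM in this assay, at which 3 of the 3 values shown sit, and has no exact value.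

Compound 4 `CC(C)[C@H]1C(O)=C(C2=NS(=O)(=O)c3c(OCc4ncon4)cccc32)C(=O)N1Cc1ccccc1` is made from compound 1 by one change: (1,2,4-oxadiazol-3-yl)methyl in place of hydrogen on an oxygen on an aromatic ring in short, (1,2,4-oxadiazol-3-yl)methyl in place of hydrogen on an oxygen on an aromatic ring.

Two measured changes of the same kind bear on this: a step that the two limits leave unreadable from compound 1 to compound 2 and a step that the two limits leave unreadable from compound 1 to compound 3 are the nearest guides. Neither has a size that can be read, yet neither compound gave a number under the limit, so no step beyond the scatter is expected in either direction. The estimated step that the limit leaves unreadable from compound 1 to compound 4 is what that reasoning gives. For compound 4 the estimate is 40000 nM within an expected range of 18000 nM to 90000 nM and the assay will probably report only a limit again.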

Compound 4, half-maximal cytotoxic concentration: > 33000 nM
Compound 4: only a limit was reported; the forecaster's own chance of this, stated with the estimate: 85%; the middle value is on the limit's open side.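

Compound 4 gives only a limit of the assay, so no step between compound 4 and compounds 1, 2 or 3 can be read in this assay: the limit of > 33000 nM in this assay, at which 4 of the 4 values shown sit.

The concentration at which any of these compounds would harm the cells stays open, as does whether the groups on the oxygen differ in this respect.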